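A few compounds are considered here, and "the series" means these few. Any claim that something is new, unique, unknown or untested is made for them only; others in the source may bear on it.

Compound 1 `COc1cncc(C2=CC3CC(C2)CN(C)C3)c1` gives 27%.
Compound 2 `C1=C(c2ccc(-c3ccccc3)nc2)CC2CNCC1C2` gives 17%.

Both were measured in an in vitro functional assay on SH-SY5Y cells for agonist activity at Neuronal acetylcholine receptor; alpha3/beta4 (Homo sapiens), read by FLIPR and calcium flux; on this read-out lower numbers stand for smaller maximal responses and higher numbers for larger maximal responses. Compound 1 and compound 2 give numbers that lie within the usual scatter of each other, so on the largest response reached neither stands apart from the other. Compound 3 `CC(C)Oc1cncc(C2=CC3CC(C2)CN(C)C3)c1` differs from compound 1 in one place: isopropyl in place of methyl on an oxygen on an aromatic ring. Going by the values given here, no measured pair shares this change, so the expectation rests on compound 1 alone. The step of a number 2 percentage points lower from compound 1 to compound 3 (within the scatter) is expected to stay within the scatter, in no particular direction. Compound 3 is therefore estimated at 25%, with a range from 10% to 45%.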

Compound 3, largest response reached (reported as percent of maximum), in percent of the reference or control that the assay uses: 15%
The estimate for compound 3 lay 10 percentage points above the measured number, and the stated range covers the measured number.
By their numbers in this assay, from the lowest: compounds 3, 2 and 1 (each within the scatter of the next, the first and the last beyond it).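

In this assay, isopropyl in place of methyl on an oxygen on an aromatic ring gives a number 12 percentage points lower from compound 1 to compound 3 (beyond the scatter). Going by these compounds alone, this is the first single change, and it shows that the group on this oxygen can alter the largest response reached, with the rest of the core of compound 1 held constant. Nothing available explains this fall. The compounds shown leave open whether ethyl would give a number between those of methyl and isopropyl, and whether a longer chain would lower it further. They also leave open how a hydroxyl in place of methoxy would behave.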